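Trifluoromethyl for fluoro on the benzyl group

A few compounds are considered here, and "the series" means these few. Any claim that something is new, unique, unknown or untested is made for them only; others in the source may bear on it.

Two compounds of this series carry a measurement in a functional assay on MCF7 cells (Homo sapiens) for antiproliferative activity, read by sulforhodamine B assay, with a stated time of 48 h; a lower number here means a stronger inhibitor of growth, a higher number a weaker inhibitor of growth. Compound 1 `O=C(NCc1cn(Cc2ccc(C(F)(F)F)cc2)nn1)c1cn(-c2ccccc2)nc1-c1ccccc1` gives 840 nM. Compound 2 `COc1ccc(-c2nn(-c3ccccc3)cc2C(=O)NCc2cn(Cc3ccc(F)cc3)nn2)cc1` gives 460 nM; this is the lower of the two numbers, yet the gap to compound 1 lies within the scatter, so the two values show no difference that can be trusted. Going by the values given here, compound 1 and compound 2 differ in more than one place, and no single step between them is available.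

Compound 3 `COc1ccc(-c2nn(-c3ccccc3)cc2C(=O)NCc2cn(Cc3ccc(C(F)(F)F)cc3)nn2)cc1` has not yet been measured in this assay . It differs from compound 2 by one change: trifluoromethyl in place of fluoro on an aromatic carbon. Among the compounds with values here, no pair of measured compounds carries this change alone, so nothing in the data sets its size or direction. The expectation for the step from compound 2 to compound 3 is therefore no change beyond the scatter, a 1.3-fold higher number from compound 2 to compound 3 (0.12 log units; within the scatter). On these data alone, on that basis compound 3 is expected to give about 600 nM in this assay , with a range from 250 nM to 1500 nM, the width of the range reflecting that the step itself is untested.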

Compound 3, concentration for 50% growth inhibition: > 100000 nM
Compound 3 ended at the assay's limit; the forecaster's own chance of this, stated with the estimate: 3%; at least 160-fold (2.22 log units) between middle value and limit.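

Compound 3 stands at a limit of this assay, so its entry is a bound and not a number: the limit of > 100000 nM in this assay, at which 1 of the 3 values shown sits. With the methoxy group kept, 4-(trifluoromethyl)benzyl in place of 4-fluorobenzyl gives an at least 210-fold higher number from compound 2 to compound 3 (2.33 log units; beyond the scatter), so a change that looks small on paper, from one fluorine to a trifluoromethyl group on that aromatic carbon, can decide whether any growth inhibition is seen at all. With the 4-(trifluoromethyl)benzyl group kept, methoxy in place of hydrogen on an aromatic carbon gives an at least 110-fold higher number from compound 1 to compound 3 (2.07 log units; beyond the scatter), so the trifluoromethyl group does not end the activity wherever it stands, and the size of its step depends on what else the molecule carries.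

The compounds shown do not say whether a chloro, methyl or nitrile group on that benzyl carbon, with the methoxy group kept, would stay with compound 2 or fall with compound 3. On these data alone, they also give no reason for the loss, and whether a hydroxy group or a chloro group in place of the methoxy group would bring the same loss in the presence of trifluoromethyl remains open.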